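This account rests on a few compounds, and the source may have more. Where it says the series, first, only, none or still open, it means among the compounds named here.

Notes on the series, all on a shared nucleoside core. Compound 1 `Nc1nc(N)c2c(-c3ccoc3)cn([C@@H]3O[C@H](CO)[C@@H](O)[C@H]3O)c2n1` is read in a functional assay on HL-60 cells (Homo sapiens) for antiproliferative activity, read by XTT assay, with a stated time of 72 h; a higher number here means a weaker inhibitor, a lower number a stronger inhibitor. In this assay compound 1 returns only a limit, > 20000 nM. Compound 2 `Cc1nc(N)c2c(-c3cc4ccccc4o3)cn([C@@H]3O[C@H](CO)[C@@H](O)[C@H]3O)c2n1` likewise returns only a limit in this assay, > 20000 nM. Compound 3 `Nc1nc(N)c2c(-c3ccccc3)cn([C@@H]3O[C@H](CO)[C@@H](O)[C@H]3O)c2n1` also gives only a limit in this assay, > 15000 nM. Compound 3 therefore stands among three values that are all limits, and the step that the two limits leave unreadable from compound 1 to compound 3 cannot be read, its two ends resting on the limit of > 15000 nM in this assay, at which 1 of the 3 values shown sits, and (the limit of > 20000 nM in this assay, at which 2 of the 3 values shown sit).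

Compound 4 `Cc1nc(N)c2c(-c3ccccc3)cn([C@@H]3O[C@H](CO)[C@@H](O)[C@H]3O)c2n1` is not yet measured. It differs from compound 3 by methyl in place of amino on an aromatic carbon. For the measured compounds named here, no measured step bears on this change directly; the nearest comparison is compound 2, which carries the methyl group and sits at the limit of > 20000 nM in this assay, at which 2 of the 3 values shown sit. With every value at a limit, no direction can be assigned, and compound 4 is expected to remain unreadable as well. The expected step is a step that the limit leaves unreadable from compound 3 to compound 4, nothing beyond the scatter. Compound 4 is estimated at 30000 nM, with a range from 10000 nM to 100000 nM.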

Compound 4, half-maximal inhibitory concentration: > 20000 nM
Compound 4: no number, only a limit; the forecaster's own chance of this, stated with the estimate: 85%; the middle value lies beyond the limit too.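

Compound 4 returns only a limit in this assay, > 20000 nM, so its steps from compound 3 and from compound 2 cannot be read. The compounds shown leave open whether amino or methyl, or any of the aromatic groups, changes the result in this assay: all four values are limits.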